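The compounds below may be only part of what the source reports. "The series", "measured", "known", "first", "only" and "open" are said of these compounds alone.

Measured in a functional assay on MCF7 cells (Homo sapiens) for antiproliferative activity, read by MTT assay, with a stated time of 72 h; on this read-out higher numbers stand for weaker inhibition and lower numbers for stronger inhibition:
- Compound 1 `COc1cc(-n2cnc3ccc(-c4cccc(O)c4)cc32)cc(OC)c1OC`: 350 nM
- Compound 2 `COc1cc(-n2cnc3ccc(-c4cccc(F)c4)cc32)cc(OC)c1OC`: 2350 nM
- Compound 3 `COc1cc(-n2cnc3ccc(-c4cccc(C)c4C)cc32)cc(OC)c1OC`: 2150 nM

These three compounds share a core and differ only in the aryl group it carries. Compound 3, with its 2,3-dimethylphenyl group, stands level with the 3-fluorophenyl compound, since a 1.1-fold lower number from compound 2 to compound 3 (0.04 log units; within the scatter) stays within the scatter. The 3-hydroxyphenyl compound is set apart from it by a 6.1-fold higher number from compound 1 to compound 3 (0.79 log units; beyond the scatter).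

The next compound is compound 4 `COc1cc(-n2cnc3ccc(-c4ccc(C)cc4)cc32)cc(OC)c1OC`, in which 4-methylphenyl replaces 2,3-dimethylphenyl on an aromatic carbon of the shared core: 4-methylphenyl in place of 2,3-dimethylphenyl on an aromatic carbon.

Going by the values given here, two measured steps bear on this change. The closest parallel is a 1.1-fold lower number from compound 2 to compound 3 (0.04 log units; within the scatter), an exchange between two aryl groups without a hydroxy group, and it produced no change beyond the scatter. The modest steps, a 6.7-fold higher number from compound 1 to compound 2 (0.83 log units; beyond the scatter) and a 6.1-fold higher number from compound 1 to compound 3 (0.79 log units; beyond the scatter), both start from the hydroxy compound, and neither aryl group in the present exchange carries a hydroxy group. Among the compounds with values here, with only three compounds this is thin evidence, and none of them carries 4-methylphenyl.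

No shift beyond the scatter is therefore expected in this assay, and the expected step is a 1.1-fold lower number from compound 3 to compound 4 (0.03 log units; within the scatter). For compound 4 the estimated value is 2000 nM, with an expected range from 700 nM to 5500 nM.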

Compound 4, half-maximal inhibitory concentration: 110 nM
For compound 4 the middle estimate is 18-fold (1.26 log units) above the measured one, outside the stated range (below it).
By their numbers in this assay, from the lowest: compound 4; then compound 1; then compounds 3 and 2 (each within the scatter of the next).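

In this assay, going by these compounds alone, this position proved far more sensitive to the choice of aryl group than the earlier compounds had suggested: 4-methylphenyl in place of 2,3-dimethylphenyl gave a 20-fold lower number from compound 3 to compound 4 (1.29 log units; beyond the scatter) and 4-methylphenyl in place of 3-fluorophenyl gave a 21-fold lower number from compound 2 to compound 4 (1.33 log units; beyond the scatter), so aryl groups without a hydroxy group do not all stand level. The hydroxy group of compound 1 also no longer marks the lowest number in the set, since the change to 4-methylphenyl gave a 3.2-fold lower number from compound 1 to compound 4 (0.50 log units; beyond the scatter) and compound 4 now stands apart from all three earlier compounds. Nothing available here explains why this exchange of one methyl-bearing aryl group for another has so large an effect.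

The step from compound 3 to compound 4 alters both the number of methyl groups and where a methyl group sits, so the compounds shown cannot separate these two changes. They also leave open how an unsubstituted phenyl, a 3-methylphenyl, a 4-ethylphenyl, a 4-aminophenyl or a 4-carboxyphenyl group would compare with 4-methylphenyl on the shared core.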